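Hydrazone series: removing the methoxy from compound 1

This account rests on a few compounds, and the source may have more. Where it says the series, first, only, none or still open, it means among the compounds named here.

compound 1 `COc1cccc(NN=C2C(Cl)=C(Cl)C(Cl)=C2Cl)c1` — > 3000 nM (a limit of the assay)
compound 2 `C#CCOC(=O)NN=C1C(Cl)=C(Cl)C(Cl)=C1Cl` — 800 nM
compound 3 `CC(C)(C)C(=O)NN=C1C(Cl)=C(Cl)C(Cl)=C1Cl` — 90 nM
compound 4 `ClC1=C(Cl)C(Cl)=C(Cl)C1=NNc1ccccc1` — not yet measured

All numbers come from a functional assay on RPMI-8226 cells (Homo sapiens) for cytotoxicity, read by MTT assay, with a stated time of 48 h; a higher number here means a weaker inhibitor, a lower number a stronger inhibitor. Compound 1 gives > 3000 nM there, which is a limit of the assay and not a number. On the values shown compound 1 therefore sits at the weak end of the set, at the limit of > 3000 nM in this assay, at which 1 of the 3 values shown sits. Among the compounds with values here, compound 2 at 800 nM and compound 3 at 90 nM both give real numbers, and the one step measured in this assay, an 8.9-fold lower number from compound 2 to compound 3 (0.95 log units; beyond the scatter), concerns only the group on the carbonyl carbon and leaves the rest of the molecule untouched.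

Compound 4 differs from compound 1 in one place: hydrogen in place of methoxy on an aromatic carbon. Within the data shown here, no measured step touches the six-membered aromatic ring, so the step from compound 2 to compound 3 does not bear on this change, and no size or direction of step in this assay can be drawn from the data. With compound 1 at a limit, the plain expectation is that compound 4 stays at or near that limit. Compound 4 is expected at 4000 nM, within a range of 1000 nM to 15000 nM. That estimate amounts to an expected step that the limit leaves unreadable from compound 1 to compound 4, with the starting point itself only a limit.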

Compound 4, half-maximal inhibitory concentration: 600 nM
Beside the measured number, compound 4's estimate is 6.7-fold (0.82 log units) above it, outside the stated range (below it).
By their numbers in this assay, from the lowest: compound 3; then compounds 4 and 2 (each within the scatter of the next). At a limit, above all of these: compound 1.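

In this assay, within the data shown here, hydrogen in place of methoxy on an aromatic carbon, meta to a large group, gives an at least 5.0-fold lower number from compound 1 to compound 4 (0.69 log units; beyond the scatter), the first step that touches the six-membered aromatic ring of carbon only. This shows that the ring position responds to substitution: within this pair, the compound without methoxy is the one that reads as a real number, with compound 4 at 600 nM. The step gives only a minimum size and its full extent cannot be read, because compound 1 stands at a limit of the assay: the limit of > 3000 nM in this assay, at which 1 of the 4 values shown sits.

The compounds shown leave open whether the difference is specific to methoxy or would also appear with another group on this carbon, such as a hydroxyl, a fluorine, an amine or a longer ether chain like ethoxy. They also leave open what lies behind the step, and whether the same replacement would give a step of similar size at any other carbon of the ring.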